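Chloro in Place of Cyano on the Benzyl Group

A few compounds are considered here, and "the series" means these few. Any claim that something is new, unique, unknown or untested is made for them only; others in the source may bear on it.

Measured compounds:
compound 1 `CCOc1cc(C2CCN(C)CC2)ccc1Nc1ncc2c(n1)N(Cc1ccccc1Br)[C@H](CC)C(=O)N2C`: "not determined" (no result reported)
compound 2 `CCOc1cc(C2CCN(C)CC2)ccc1Nc1ncc2c(n1)N(Cc1cccc(C#N)c1)[C@H](CC)C(=O)N2C`: 1800 nM

Compound 1 has "not determined" (no result reported) in an assay on isolated protein for inhibition of serine/threonine-protein kinase PLK1 (Homo sapiens), read by Z'-LYTE, with a stated time of 60 min; on this read-out lower numbers stand for stronger inhibition and higher numbers for weaker inhibition. Among the compounds with values here, compound 2 gives 1800 nM in this assay and is the only compound with a number here. Compound 3 `CCOc1cc(C2CCN(C)CC2)ccc1Nc1ncc2c(n1)N(Cc1cccc(Cl)c1)[C@H](CC)C(=O)N2C` differs from compound 2 by chloro in place of cyano on an aromatic carbon. Within the data shown here, no step between measured compounds is available to calibrate this change, so only a small shift in this assay is expected, within the usual scatter and with no clear direction. Compound 3 is estimated at 1500 nM, between 500 nM and 4500 nM, an expected step of a 1.2-fold lower number from compound 2 to compound 3 (0.08 log units; within the scatter).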

Compound 3, half-maximal inhibitory concentration: 540 nM
For compound 3 the middle estimate is 2.8-fold (0.44 log units) above the measured one; low and high end bracket the measured number.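

In this assay, within the data shown here, chloro in place of cyano gives a 3.3-fold lower number from compound 2 to compound 3 (0.52 log units; beyond the scatter), the first measured step at this place on the benzyl group. It shows that the number responds to the choice of group on this aromatic carbon, and that the 3-chlorobenzyl compares favourably with the 3-cyanobenzyl. Nothing at hand bears on why the number moves. Going by these compounds, whether methoxy, an amine or a carboxylic acid at this place would lower the number further remains open. So does whether the step would hold with another group elsewhere on the shared core.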